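The source may hold more compounds than are shown below. What is called first, only, known or untested is meant among the compounds shown, and "the series" means these compounds.

Compound 1 `COc1ccc2c(NC3CCCCCC3)nc(N3CCC(N4CCCC4)CC3)nc2c1` gives 10% in an in vitro functional assay on B300-19 cells for antagonist activity at C-C chemokine receptor type 4 (Homo sapiens), read by GTPgammaS binding, tested at 1 uM; a lower number here means less inhibition, a higher number more inhibition at the concentration tested (going by the name of the read-out).
Compound 2 `COc1cc2nc(N3CCC(N4CCCC4)CC3)nc(N(C)C)c2cc1OC` gives in this assay only a limit of the assay, < 0%.
Compound 3 `COc1cc2nc(N3CCC(N4CCCC4)CC3)nc(N3CCCCC3)c2cc1OC` gives 8% in this assay.

Going by the values given here, only two of the three values are plain numbers; compound 3 and compound 1 lie within the usual scatter of each other, so neither can be called weaker or stronger. The value of compound 2 is a limit, and nothing more can be read from it. Compound 4 `COc1cc2nc(N3CCC(N4CCCC4)CC3)nc(NCc3ccccc3)c2cc1OC` has not yet been measured. benzylamino in place of piperidin-1-yl on an aromatic carbon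

One measured step changes the same kind of group: a number at least 8 percentage points higher from compound 2 to compound 3 (that floor lies within the scatter). Its floor lies within the scatter, so it gives no clear size or direction for swapping one amine for another. The numbers of compound 1 and compound 3 are both low, and nothing measured points to a larger inhibition for a third amine. Compound 4 is therefore expected to give 10% in this assay, between 0% and 25%. The step of a number 2 percentage points higher from compound 3 to compound 4 (within the scatter) is expected to stay within the scatter.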

Compound 4, a percentage reported as inhibition, at one concentration (the size of the read-out at that concentration, not a potency): 10%
Estimate against measurement, compound 4: no gap at the digits printed; low and high end bracket the measured number.
By their numbers in this assay, from the lowest: compounds 3, 1 and 4 (each within the scatter of the next). At a limit, below all of these: compound 2.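

In this assay, benzylamino in place of piperidin-1-yl on this aromatic carbon gives a number 2 percentage points higher from compound 3 to compound 4 (within the scatter), so a carbon-only aromatic ring and a hydrogen-bond donor in the group at this position leave the two compounds indistinguishable. Measured against dimethylamino at the same place, the result is a number at least 10 percentage points higher from compound 2 to compound 4 (that floor lies within the scatter), which also gives no clear difference. This second step has only a floor, not a size, because compound 2 stands at a limit of the assay: the limit of < 0% in this assay, at which 1 of the 4 values shown sits.

Going by these compounds, it remains open whether any other group at this position would give an inhibition clearly beyond the scatter, for example a longer chain such as phenethylamino or a benzylamino ring carrying a carboxylic acid. On these data alone, a simple primary amine at this position is equally open.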